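Shortening the Chain: Cytotoxicity on HEL Cells

The compounds below may be only part of what the source reports. "The series", "measured", "known", "first", "only" and "open" are said of these compounds alone.

Compound 1 `CCCCCCCCCc1cc2cn(COCCO)c(O)nc-2n1` was examined in a functional assay on HEL cells (Homo sapiens), read by microscopy; a higher number here means that more compound is tolerated, a lower number that less compound is tolerated. In this assay compound 1 gives > 80000 nM, which is a limit of the assay rather than a number (the limit of > 80000 nM in this assay, at which 1 of the 2 values shown sits). Compound 2 `CCCCCCCCCC#Cc1cc2cn(COCCO)c(=O)nc2o1` gives >= 20000 nM in this assay, likewise a limit (the limit of >= 20000 nM in this assay, at which 1 of the 2 values shown sits). Compound 3 `CCCCc1cc2cn(COCCO)c(O)nc-2n1` differs from compound 1 by hydrogen in place of pentyl on a saturated chain carbon, four bonds along the chain from an aromatic carbon. Within the data shown here, no measured step between compounds differing in one place exists here, so the size of this change is open; a shorter chain is expected to move the read-out by nothing beyond the scatter, if anything upward. Compound 3 is therefore expected to give 80000 nM, between 40000 nM and 160000 nM. The step of a number no higher from compound 1 to compound 3 (the limit leaves the size open) is estimated to stay within the scatter.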

Compound 3, minimum cytotoxic concentration: > 400000 nM
Compound 3: no number, only a limit; the forecaster's own chance of this, stated with the estimate: 85%; at least 5.0-fold (0.69 log units) between middle value and limit.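

Compound 1 and compound 3 both give only limits of the assay, and the step between them cannot be read. The compounds shown leave open where either compound's minimum cytotoxic concentration actually lies, and whether hydrogen in place of pentyl changes it at all.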